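The source may report more compounds than this note shows. Statements on the series, on what has been measured and on what is new or still open speak of the compounds shown alone.

In a functional assay on SW-620 cells (Homo sapiens) for cytotoxicity, read by MTT assay, with a stated time of 48 h (on this read-out lower numbers stand for stronger inhibition and higher numbers for weaker inhibition), compound 1 `CCCCCCCCNC(=O)[C@@H](NC(=O)c1ccccc1)[C@@H](C)O` gives 200000 nM, and compound 2 `CCCCCCCCCCCCCCNC(=O)[C@@H](NC(=O)c1ccccc1)[C@@H](C)O` gives 200000 nM. Among the compounds with values here, the single measured step, no change at the digits printed from compound 1 to compound 2 (within the scatter), thus leaves compound 2 level with compound 1 on this read-out. Compound 3 `CCCCCCCCCCCCCCNC(=O)[C@@H](NS(=O)(=O)c1ccc(C)cc1)[C@@H](C)O` differs from compound 2 by (4-methylphenyl)sulfonyl in place of benzoyl on an amine nitrogen. Within the data shown here, that change sits on the amine nitrogen, a place no measured step has touched; the step from compound 1 to compound 2 altered only the alkyl chain, so it bears on compound 3 merely as a sign that the shared core has tolerated one change without any shift beyond the scatter. Among the measured compounds shown here, with no step at the amine nitrogen to draw on, compound 3 is expected to show no change at the digits printed from compound 2 to compound 3 (within the scatter), a step not expected to exceed the scatter. The estimated value for compound 3 in this assay is 200000 nM, with a range from 100000 nM to 400000 nM.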

Compound 3, half-maximal inhibitory concentration: 15200 nM
Compound 3: the middle estimate sits 13-fold (1.12 log units) above what was measured; the whole stated range lies above it.
By their numbers in this assay, from the lowest: compound 3; then compounds 1 and 2 (each within the scatter of the next).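

In this assay, the amine nitrogen proves to be a place where the read-out responds: (4-methylphenyl)sulfonyl in place of benzoyl gives a 13-fold lower number from compound 2 to compound 3 (1.12 log units; beyond the scatter), whereas the chain change gave no change at the digits printed from compound 1 to compound 2 (within the scatter). The exchange brings in the sulfonyl and the methyl on the ring together, so this single step cannot assign the shift to either of them. Nothing available explains the shift.

On these data alone, it remains open which part carries the step, and a 4-methylbenzoyl or an unsubstituted phenylsulfonyl group on the same nitrogen would separate the two. As far as these compounds go, it is equally open whether (4-methylphenyl)sulfonyl would give a similar step on the shorter chain of compound 1.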